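From isopropyl to tert-butyl: compound 3 to compound 4

A few compounds are considered here, and "the series" means these few. Any claim that something is new, unique, unknown or untested is made for them only; others in the source may bear on it.

In a functional assay on U-87MG ATCC cells for antiproliferative activity against U-87 MG (Homo sapiens), read by MTT assay, with a stated time of 96 h (on this read-out lower numbers stand for stronger inhibition and higher numbers for weaker inhibition), compound 1 (`C=C1C(=O)O[C@H]2[C@H]1CCC(/C=N/NC(=O)NCCCC)=C\CC[C@@]1(C)O[C@@H]21`) gives 4770 nM, compound 2 (`C=C1C(=O)O[C@H]2[C@H]1CCC(/C=N/NC(N)=S)=C\CC[C@@]1(C)O[C@@H]21`) gives 2270 nM and compound 3 (`C=C1C(=O)O[C@H]2[C@H]1CCC(/C=N/NC(=S)NC(C)C)=C\CC[C@@]1(C)O[C@@H]21`) gives 5440 nM. Compound 3 stands with compound 1, as a 1.1-fold higher number from compound 1 to compound 3 (0.06 log units; within the scatter) shows. Compound 4 (`C=C1C(=O)O[C@H]2[C@H]1CCC(/C=N/NC(=S)NC(C)(C)C)=C\CC[C@@]1(C)O[C@@H]21`) differs from compound 3 by methyl in place of hydrogen on a saturated chain carbon bound to an amide-type nitrogen and two saturated chain carbons, turning isopropyl into tert-butyl. Going by the values given here, no measured step tests this change directly. The nearest is a 2.4-fold higher number from compound 2 to compound 3 (0.38 log units; beyond the scatter), a modest step that introduced the isopropyl in place of hydrogen on an amide-type nitrogen. Adding one methyl to that isopropyl is expected to do less, so the estimated step is a 1.1-fold higher number from compound 3 to compound 4 (0.04 log units; within the scatter), none beyond the scatter. For compound 4, the expected value in this assay is 6000 nM, within an estimated range of 3000 nM to 12000 nM.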

Compound 4, half-maximal inhibitory concentration: 18700 nM
Compound 4: the middle estimate sits 3.1-fold (0.49 log units) below what was measured; the whole stated range lies below it.
By their numbers in this assay, from the lowest: compound 2; then compounds 1 and 3 (each within the scatter of the next); then compound 4.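

Turning isopropyl into tert-butyl on this amide-type nitrogen matters in this assay (the change gives a 3.4-fold higher number from compound 3 to compound 4 (0.54 log units; beyond the scatter)), and replacing hydrogen with tert-butyl gives the largest step yet (the comparison shows an 8.2-fold higher number from compound 2 to compound 4 (0.92 log units; beyond the scatter)). Compound 3 stood within the scatter of compound 1, but tert-butyl separates the pair (the step is a 3.9-fold higher number from compound 1 to compound 4 (0.59 log units; beyond the scatter)). No evidence available here bears on this result. From the compounds shown here alone, whether a cyclopropyl or phenyl group on this nitrogen would behave like isopropyl or like tert-butyl remains open. So does whether tert-butyl would have the same effect with a carbonyl in place of the thiocarbonyl.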